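The source may report more compounds than this note shows. Statements on the series, on what has been measured and on what is new or still open speak of the compounds shown alone.

Values so far in a functional assay on HCT-116 cells (Homo sapiens) for cytotoxicity, read by hypoxanthine incorporation, with a stated time of 72 h, tested at 10 uM; a lower number here means less inhibition of growth, a higher number more inhibition of growth at the concentration tested
- compound 1 `CC(C)C[C@@H]1NC(=O)[C@H](Cc2ccccc2)NC(=O)[C@H](CCCCNC(=O)OC(C)(C)C)NC(=O)[C@H](CC(C)C)NC(=O)[C@H](C(C)C)NC1=O` gives 0%
- compound 2 `CC(C)C[C@@H]1NC(=O)[C@H](Cc2ccccc2)NC(=O)[C@H](CCCCNC(=O)OC(C)(C)C)N(C)C(=O)[C@H](CC(C)C)NC(=O)[C@H](C(C)C)NC1=O` gives 58%

Within the data shown here, compound 1 stands lowest of the two, and compound 2 is its only neighbour on the scale. The next compound to be tested is compound 3 `CC(C)C[C@@H]1NC(=O)[C@H](Cc2ccccc2)NC(=O)[C@H](CCCCNC(=O)OC(C)(C)C)NC(=O)[C@H](CC(C)C)NC(=O)[C@@H](C(C)C)NC1=O`. Relative to compound 1, (the two compounds have the same atoms and bonds and differ only in configuration as drawn: 1 of 5 stereo elements differ; a stereocentre at a saturated ring carbon is drawn S in compound 1 and R in compound 3). In words, a stereocentre at a saturated ring carbon is drawn S in compound 1 and R in compound 3.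

Among the measured compounds shown here, only one measured step is available, a number 58 percentage points higher from compound 1 to compound 2 (beyond the scatter), for methyl in place of hydrogen on an amide-type nitrogen in a ring. That step is large but is a different kind of change, and no change of configuration has yet been measured in this series. It shows only that a single edit to the core of compound 1 can move the number far. With compound 1 at 0% in this assay, a real change is expected to appear as a rise. A modest rise is expected, with the estimated step being a number 15 percentage points higher from compound 1 to compound 3 (beyond the scatter). For compound 3 the expected value is 15%, with an estimated range of 0% to 55%.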

Compound 3, percent growth inhibition at one concentration: 9%
Compound 3: middle estimate off by 6 percentage points, on the high side; the range from low to high includes it.
By their numbers in this assay, from the lowest: compounds 1 and 3 (each within the scatter of the next); then compound 2.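

In this assay, among these compounds, the change of a stereocentre at a saturated ring carbon, drawn S in compound 1 and R in compound 3, gives a number 9 percentage points higher from compound 1 to compound 3 (within the scatter), the first measured change of configuration. The earlier step, a number 58 percentage points higher from compound 1 to compound 2 (beyond the scatter), showed that one edit to the core of compound 1 can move the number far, whereas this pair shows that an inversion at this one carbon need not do so at the single concentration tested. The reading of this pair concerns one variable alone, with no group entering or leaving: the fact that compounds 1 and 3 differ only in the configuration as drawn.

Going by these compounds, it remains open whether the same inversion would also leave the number within the scatter in the presence of the methyl on the amide-type nitrogen of compound 2, and whether the other stereo elements of the core would behave as this one does. Also open, on these data alone, is how the number in this assay would respond to a free amine in place of the carbamate, which would test a change of group rather than of configuration.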